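Series notes: substituent swaps on the aryl ring

The source may hold more compounds than are shown below. What is called first, only, known or untested is meant among the compounds shown, and "the series" means these compounds.

Two compounds of this series have numbers in a functional assay for inhibition, tested at 60 ug/mL; a higher number here means a stronger effect of the compound at the concentration tested, a lower number a weaker effect. Compound 1 `COc1cccc(-c2cc(-c3cc(C(C)C)c(O)cc3C)[nH]c(=O)c2C#N)c1` gives 38% in this assay. Compound 2 `Cc1cc(O)c(C(C)C)cc1-c1cc(-c2ccccc2[N+](=O)[O-])c(C#N)c(=O)[nH]1` gives 31% in this assay, and the step of a number 7 percentage points lower from compound 1 to compound 2 (within the scatter) is within the scatter, so the two compounds stand level on the numbers shown.

Compound 3 `Cc1cc(O)c(C(C)C)cc1-c1cc(-c2ccccc2Cl)c(C#N)c(=O)[nH]1` is not yet measured. It differs from compound 2 by chloro in place of nitro on an aromatic carbon. Within the data shown here, no measured step covers this particular exchange; the only step known, a number 7 percentage points lower from compound 1 to compound 2 (within the scatter), concerns a different exchange on the same aromatic carbon and was within the scatter. On that basis no step beyond the scatter is expected from compound 2 to compound 3, and the expected step is a number 2 percentage points higher from compound 2 to compound 3 (within the scatter). Compound 3 is therefore estimated at 33% in this assay, with a range from 18% to 48%.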

Compound 3, a percentage reported as inhibition, at one concentration (the size of the read-out at that concentration, not a potency): 26%
Compound 3: middle estimate off by 7 percentage points, on the high side, within the range that was stated.
By their numbers in this assay, from the lowest: compounds 3, 2 and 1 (each within the scatter of the next, the first and the last beyond it).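

In this assay the exchange of nitro for chloro on the aromatic carbon gives a number 5 percentage points lower from compound 2 to compound 3 (within the scatter) so at this position the two groups stand level, even though chloro brings one heavy atom and no hydrogen-bond acceptors in place of the three heavy atoms and two acceptors of nitro. Among these compounds, the only step beyond the scatter here is a number 12 percentage points lower from compound 1 to compound 3 (beyond the scatter) with 2-chlorophenyl replacing 3-methoxyphenyl, while compound 2 with its 2-nitrophenyl stays within the scatter of both others. No measurement at hand accounts for these numbers.

Still open, going by these compounds, is whether an amine or a carboxylic acid on this aromatic carbon would move the number beyond the scatter. 2-chlorophenyl and 3-methoxyphenyl differ in both group and placement, so the larger step cannot be assigned to either alone.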